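Replacing Bromo with Carboxy in Compound 2

A few compounds are considered here, and "the series" means these few. Any claim that something is new, unique, unknown or untested is made for them only; others in the source may bear on it.

Compound 1 `Cc1cccc(C)c1/C=C/[C@](C)(O)CC[C@@H]1[C@@]2(C)CCCC(C)(C)[C@@H]2CC[C@@]1(C)O`: 278 nM
Compound 2 `CC1(C)CCC[C@]2(C)[C@@H](CC[C@@](C)(O)/C=C/c3ccc(Br)cc3)[C@](C)(O)CC[C@@H]12`: 41300 nM

In a functional assay on PC-3 cells (Homo sapiens) for cytotoxicity, read by MTT assay, with a stated time of 48 h (on this read-out higher numbers stand for weaker inhibition and lower numbers for stronger inhibition), compound 2 stands highest of the two measured compounds, at 41300 nM. Compound 3 `CC1(C)CCC[C@]2(C)[C@@H](CC[C@@](C)(O)/C=C/c3ccc(C(=O)O)cc3)[C@](C)(O)CC[C@@H]12` differs from it in one place: carboxy in place of bromo on an aromatic carbon. For the measured compounds named here, the only measured step touching this position is a 150-fold higher number from compound 1 to compound 2 (2.17 log units; beyond the scatter). That large change lies beyond the scatter, but it is a different replacement, so it gives no direct guide to size or direction. No step beyond the scatter is firmly expected, and the estimated step is a 1.2-fold lower number from compound 2 to compound 3 (0.07 log units; within the scatter). For compound 3 the estimated value is 35000 nM, with an expected range of 9000 nM to 120000 nM.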

Compound 3, half-maximal inhibitory concentration: 102 nM
Beside the measured number, compound 3's estimate is 340-fold (2.54 log units) above it; the whole stated range lies above it.
By their numbers in this assay, from the lowest: compound 3; then compound 1; then compound 2.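

In this assay, this aromatic carbon proves highly sensitive to the group it carries: carboxy in place of bromo gives a 400-fold lower number from compound 2 to compound 3 (2.61 log units; beyond the scatter) on an otherwise unchanged structure. The 4-bromophenyl result therefore does not speak for all singly substituted phenyl groups on this chain, as 4-carboxyphenyl in place of 2,6-dimethylphenyl gives a 2.7-fold lower number from compound 1 to compound 3 (0.44 log units; beyond the scatter) and places compound 3 lowest of the three. No supporting measurement accounts for this change. From the compounds shown here alone, whether the carboxy group itself is needed remains open, and a methyl ester, a primary amide or a tetrazole at this carbon would test that.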